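The source may hold more compounds than are shown below. What is called first, only, known or untested is meant among the compounds shown, and "the series" means these compounds.

Measured in an ADME assay on cells (Hepatocyte, Rattus norvegicus) for pharmacokinetics, read by LC-MS, with a stated time of 90 min, tested at 1 uM; a higher number here means faster removal of the compound, a lower number slower removal:
Compound 1 `COC(=O)N(Cc1cccc(F)c1)c1c(N)nc(-c2nn(Cc3ccccc3F)c3ncccc23)nc1N` gives 53.3 mL/min/kg
Compound 2 `CC(C)OC(=O)Nc1c(N)nc(-c2nn(Cc3ccccc3F)c3ncccc23)nc1N` gives 15 mL/min/kg

Of these two, compound 2 has the lower number (15 mL/min/kg) and compound 1 the higher (53.3 mL/min/kg), and the gap between them lies beyond the scatter. Compound 3 `Nc1nc(-c2nn(Cc3ccccc3F)c3ncccc23)nc(N)c1NC(=O)OCC(F)(F)F` has not yet been measured. It differs from compound 2 by one change (2,2,2-trifluoroethyl in place of isopropyl on an oxygen next to a carbonyl group), with 2,2,2-trifluoroethyl in place of isopropyl on an oxygen next to a carbonyl group. For the measured compounds named here, no measured pair shows this change, so compound 2 at 15 mL/min/kg is the only close reference. In this assay the expected step is small: a 1.2-fold higher number from compound 2 to compound 3 (0.08 log units; within the scatter) is the estimate, slightly upward and within the usual scatter. For compound 3 the estimated value is 18 mL/min/kg with an expected range of 8 mL/min/kg to 40 mL/min/kg for the coming measurement.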

Compound 3, clearance: 35 mL/min/kg
The estimate for compound 3 lay 1.9-fold (0.29 log units) below the measured number; the measured number falls inside the stated range.
By their numbers in this assay, from the lowest: compound 2; then compounds 3 and 1 (each within the scatter of the next).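

Until this result, no pair of compounds differed in one place, so this assay had shown no step at the position on an oxygen next to a carbonyl group. Placing 2,2,2-trifluoroethyl there in place of isopropyl gives a 2.3-fold higher number from compound 2 to compound 3 (0.37 log units; beyond the scatter) and so shows that the group on this oxygen can shift the clearance read-out, at least in this one pair. Nothing measured here bears on why the number rises.

A single pair cannot show whether the step would carry over to the core of compound 1, which also bears a substituted nitrogen and a different group on the same oxygen. As far as these compounds go, how a longer chain such as n-butyl, or a ring such as cyclopropyl, would read on this oxygen also remains open.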